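The compounds below may be only part of what the source reports. "The series", "measured", "known", "first", "only" and "open" are said of these compounds alone.

Two compounds with a measured value in an ADME assay on the whole organism with Oryza sativa as the target, tested at 0.1 uM (a higher number here means a weaker effect of the compound at the concentration tested, a lower number a stronger effect), share one core and differ in the ring that carries the urea. Compound 1 `C[C@H](NC(=O)Nc1ccc(F)cc1)c1ccccc1` gives 96% in this assay. Compound 2 `Cc1cc(F)ccc1NC(=O)N[C@H](C)c1ccccc1` gives 100% in this assay, and the two numbers lie within the usual scatter of each other, so no order can be read from them. No step between a pair of measured compounds is shown for this series.

Compound 3 `Cc1cc(F)ccc1NC(=O)N[C@@H](C)c1ccccc1` is not yet measured in this assay. Between compound 2 and compound 3, (the two compounds have the same atoms and bonds and differ only in configuration as drawn: 1 of 1 stereo elements differ; a stereocentre at a saturated chain carbon is drawn R in compound 2 and S in compound 3). Since nothing here shows how the drawn configuration changes this assay, the expected step from compound 2 to compound 3, a number 4 percentage points lower from compound 2 to compound 3 (within the scatter), is none beyond the scatter. Compound 3 is therefore estimated to give 96% in this assay, within a range from 82% to 100%.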

Compound 3, a percentage reported as activity, at one concentration (the size of the read-out at that concentration, not a potency): 99%
Estimate against measurement, compound 3: 3 percentage points below; the range from low to high includes it.
By their numbers in this assay, from the lowest: compounds 1, 3 and 2 (each within the scatter of the next).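

In this assay, the stereocentre at the saturated chain carbon now has a step of its own, a number 1 percentage points lower from compound 2 to compound 3 (within the scatter), and that step can be tied to this centre alone because of one fact: the fact that compounds 2 and 3 differ only in the configuration as drawn. Drawing this centre R or S therefore produces no change that can be told from the scatter in this pair. Methyl in place of hydrogen on an aromatic carbon now also has a reading in a single step, a number 3 percentage points higher from compound 1 to compound 3 (within the scatter), which likewise gives no order.

As far as these compounds go, whether a chloro group, a methoxy group or a carboxylic acid on the ring that carries the urea would move the read-out beyond the scatter remains open. From the compounds shown here alone, it is also open whether the change of configuration behaves the same way on a core without the methyl.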